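The source may report more compounds than this note shows. Statements on the series, on what has been measured and on what is new or still open speak of the compounds shown alone.

Compounds measured in a functional assay on SK-BR-3 cells (Homo sapiens) for antiproliferative activity, read by MTT assay, with a stated time of 72 h; a lower number here means a stronger inhibitor, a higher number a weaker inhibitor:
compound 1 `CCN1CCN(c2cc(C)c3cc(NC(=O)c4cccc(Cl)c4)ccc3n2)CC1` gives 17800 nM
compound 2 `CCN1CCN(c2cc(C)c3cc(NC(=O)c4ccc5ccccc5n4)ccc3n2)CC1` gives 3760 nM
compound 3 `CCN1CCN(c2cc(C)c3cc(NC(=O)c4cccc(F)c4)ccc3n2)CC1` gives 24900 nM

Compound 3 has the highest of the three numbers. Its nearest neighbour is compound 1, with a 1.4-fold higher number from compound 1 to compound 3 (0.15 log units; within the scatter), a step within the scatter, so the two cannot be ordered. The furthest is compound 2, with a 6.6-fold higher number from compound 2 to compound 3 (0.82 log units; beyond the scatter), a modest step beyond the scatter.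

Compound 4 `CCN1CCN(c2cc(C)c3cc(NC(=O)c4ccc(F)cc4)ccc3n2)CC1` differs from compound 3 in one place: 4-fluorophenyl in place of 3-fluorophenyl on a carbonyl carbon.

For the measured compounds named here, none of the measured steps moves a substituent to another position on the same ring. The step of a 1.4-fold higher number from compound 1 to compound 3 (0.15 log units; within the scatter) swaps one halogen for another at the same place and stays within the scatter; the steps of a 4.7-fold lower number from compound 1 to compound 2 (0.68 log units; beyond the scatter) and a 6.6-fold higher number from compound 2 to compound 3 (0.82 log units; beyond the scatter) replace the whole phenyl ring with quinolin-2-yl and are modest. There is no measured basis for a shift in either direction, so no step beyond the scatter is expected for compound 4, and its estimate is a 1.0-fold higher number from compound 3 to compound 4 (0.00 log units; within the scatter).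

In this assay compound 4 is therefore expected to give 25000 nM, between 10000 nM and 60000 nM.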

Compound 4, half-maximal inhibitory concentration: 19800 nM
Beside the measured number, compound 4's estimate is 1.3-fold (0.10 log units) above it; the measured number falls inside the stated range.
By their numbers in this assay, from the lowest: compound 2; then compounds 1, 4 and 3 (each within the scatter of the next).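

In this assay, for the compounds shown here, this is the first change that moves the fluoro group around the ring on the carbonyl carbon, and the swap of 3-fluorophenyl for 4-fluorophenyl gives a 1.3-fold lower number from compound 3 to compound 4 (0.10 log units; within the scatter), so the two cannot be ordered. The 4-fluorophenyl group also cannot be told apart from 3-chlorophenyl, at a 1.1-fold higher number from compound 1 to compound 4 (0.05 log units; within the scatter), while quinolin-2-yl stays separated from this new ring as well, at a 5.3-fold higher number from compound 2 to compound 4 (0.72 log units; beyond the scatter), a modest step. Nothing measured here accounts for these results.

As far as these compounds go, it remains open whether a methoxy group, an amine or a carboxylic acid on the phenyl ring would move the number beyond the scatter. From the compounds shown here alone, it is also open whether a pyridin-2-yl or naphthalen-2-yl group on the carbonyl carbon would match quinolin-2-yl.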